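The source may hold more compounds than are shown below. What is called first, only, known or untested is meant among the compounds shown, and "the series" means these compounds.

Measured in a functional assay on A549 cells (Homo sapiens) for cytotoxicity, read by MTT assay, with a stated time of 72 h; a higher number here means a weaker inhibitor, a lower number a stronger inhibitor:
compound 1 `O=C(N/N=C/c1ccc([N+](=O)[O-])cc1)Nc1cc2c(Nc3ccc(F)c(Cl)c3)ncnc2cc1O[C@H]1CCOC1`: 31200 nM
compound 2 `O=C(N/N=C/c1ccc(F)cc1Cl)Nc1cc2c(Nc3ccc(F)c(Cl)c3)ncnc2cc1O[C@H]1CCOC1`: 27200 nM
compound 3 `COc1ccc(/C=N/NC(=O)Nc2cc3c(Nc4ccc(F)c(Cl)c4)ncnc3cc2O[C@H]2CCOC2)cc1`: 33100 nM

These three compounds share one core and differ only in the aromatic group on a carbon with a double bond to nitrogen. Compound 3 stands level with the other two, as the measured steps show: a 1.1-fold higher number from compound 1 to compound 3 (0.03 log units; within the scatter) and a 1.2-fold higher number from compound 2 to compound 3 (0.09 log units; within the scatter). Both lie within the scatter, so compound 3 cannot be told apart from either neighbour.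

The next compound is compound 4 `COc1ccc(/C=N/NC(=O)Nc2cc3c(Nc4ccc(F)c(Cl)c4)ncnc3cc2O[C@H]2CCOC2)c(OC)c1OC`, which changes that same group: 2,3,4-trimethoxyphenyl in place of 4-methoxyphenyl on a carbon with a double bond to nitrogen. Put simply, 2,3,4-trimethoxyphenyl takes the place of 4-methoxyphenyl.

Among the compounds with values here, the steps that bear on this change are the swaps already made at this place. Besides the two above, there is a 1.1-fold lower number from compound 1 to compound 2 (0.06 log units; within the scatter), also within the scatter. So far, then, three different groups here have given values in this assay that cannot be separated. None of these compounds carries more than one methoxy group, however, so the data do not test that kind of change directly, and the range must stay wide.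

No step beyond the scatter is expected, and the expected step is a 1.1-fold lower number from compound 3 to compound 4 (0.04 log units; within the scatter). The estimate for compound 4 is 30000 nM, with an expected range from 14000 nM to 60000 nM.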

Compound 4, half-maximal inhibitory concentration: 25200 nM
Estimate against measurement, compound 4: 1.2-fold (0.08 log units) above; the range from low to high includes it.
By their numbers in this assay, from the lowest: compounds 4, 2, 1 and 3 (each within the scatter of the next).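

Within the data shown here, three methoxy groups on the ring are tested here for the first time, and in this assay the larger 2,3,4-trimethoxyphenyl group, with 12 heavy atoms and 3 hydrogen-bond acceptors against 8 and 1 for 4-methoxyphenyl, cannot be told apart from it: a 1.3-fold lower number from compound 3 to compound 4 (0.12 log units; within the scatter). The same holds against the two halogen-bearing and nitro-bearing groups, with a 1.1-fold lower number from compound 2 to compound 4 (0.03 log units; within the scatter) and a 1.2-fold lower number from compound 1 to compound 4 (0.09 log units; within the scatter), so four different aromatic groups on this carbon with a double bond to nitrogen now give values that cannot be separated. The compounds shown come with no separate measurement that could account for this flat picture.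

As far as these compounds go, all four groups are six-membered aromatic rings of carbon only, so it remains open whether this insensitivity would survive a carboxylic acid or an amine on that ring, or a plain alkyl chain in place of the ring. All four compounds also share one core and one cell assay, so the data cannot say whether the same holds with a change elsewhere on the core or in other cells.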